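The compounds below may be only part of what the source reports. "The series", "measured", "known", "first", "only" and "open" are said of these compounds alone.

Of the compounds shown here, three sharing one core have been measured in a physicochemical assay for solubility, in phosphate buffer, measured as kinetic solubility; on this read-out lower numbers stand for lower solubility and higher numbers for higher solubility. Compound 1 `CC(C)C(/C=C1\OC(=O)NC1=O)c1cc(Cl)c(-c2ccc3cccc(F)c3c2)[nH]c1=O` gives 21500 nM in this assay. Compound 2 `O=C1NC(=O)/C(=C/C(c2ccc(-c3ccc4cccc(F)c4c3)[nH]c2=O)C2CC2)O1` gives 30800 nM, and compound 3 `CCC(CC)C(/C=C1\OC(=O)NC1=O)c1ccc(-c2ccc3cccc(F)c3c2)[nH]c1=O` gives 33700 nM. Compound 1 has the lowest of the three numbers, but its gaps to compound 2 and to compound 3 are both within the scatter, so the three cannot be told apart with confidence. Among the measured compounds shown here, the only single-point step among the measured compounds, a 1.1-fold higher number from compound 2 to compound 3 (0.04 log units; within the scatter), exchanges one saturated group for another and stays within the scatter.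

Compound 4 `Cc1cc(C(/C=C2\OC(=O)NC2=O)C(C)C)c(=O)[nH]c1-c1ccc2cccc(F)c2c1` has not yet been measured. It differs from compound 1 in one place: methyl in place of chloro on an aromatic carbon. This exchanges one small group for another on the core, with donors, acceptors and charge unchanged, as the counted difference shows. For the measured compounds named here, no measured step covers this kind of exchange; the one step available concerns a different position and was itself within the scatter. There is thus no basis for expecting a shift beyond the scatter. The step expected is therefore a 1.1-fold higher number from compound 1 to compound 4 (0.05 log units; within the scatter), within the scatter in either direction. Compound 4 is estimated at 24000 nM, with a range from 10000 nM to 55000 nM.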

Compound 4, solubility: 35700 nM
Compound 4: the middle estimate sits 1.5-fold (0.17 log units) below what was measured; low and high end bracket the measured number.
By their numbers in this assay, from the lowest: compounds 1, 2, 3 and 4 (each within the scatter of the next).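

In this assay, the exchange of chloro for methyl on this aromatic carbon, two atoms from the ring nitrogen, gives a 1.7-fold higher number from compound 1 to compound 4 (0.22 log units; within the scatter). Among the compounds shown here, this is the first step that reports on this position, as the only earlier step, from cyclopropyl to pentan-3-yl, concerned a group on the chain rather than on the aromatic ring. It shows that here one single-atom group can take the place of another, with the counted donors, acceptors and charge unchanged, without a shift that can be told from the scatter, and no measurement at hand explains where the number falls.

Chloro and methyl are the only groups shown at this position, each with a single heavy atom, so it remains open whether a methoxy group, an amine, a carboxylic acid or a longer chain there would give a step beyond the scatter. Going by these compounds, it is also open whether the exchange of chloro for methyl would read the same with cyclopropyl or pentan-3-yl on the chain carbon instead of the group carried by compound 1 and compound 4.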